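Pyridylmethyl Amide Expected to Stay Within Scatter of Phenyl Amides

The source may report more compounds than this note shows. Statements on the series, on what has been measured and on what is new or still open speak of the compounds shown alone.

Within the data shown here, both compounds measured so far share one core and differ only in the group carried on an amide-type nitrogen. Compound 1 `O=C(NCc1ccccc1)c1c(O)c2cccnc2n(-c2ccccc2)c1=O` gives 11.3% in a functional assay on the whole organism for inhibition, with Rattus norvegicus as the target, read by cytopathic effect and paw edema, at a dose of 100 mg/kg by the oral route; on this read-out lower numbers stand for less inhibition and higher numbers for more inhibition at the one dose given (going by the name of the read-out). Compound 2 `Cc1ccccc1NC(=O)c1c(O)c2cccnc2n(-c2ccccc2)c1=O` gives 9.8% in this assay. Among the measured compounds shown here, on these two numbers compound 2 stands lowest, with compound 1 as its nearest neighbour; the only measured step, a number 1.5 percentage points lower from compound 1 to compound 2 (within the scatter), lies within the scatter, so the two cannot be told apart. Compound 3 `O=C(NCc1cccnc1)c1c(O)c2cccnc2n(-c2ccccc2)c1=O` has not yet been measured. It differs from compound 2 in a single place: (pyridin-3-yl)methyl in place of 2-methylphenyl on an amide-type nitrogen. For the measured compounds named here, the one measured step that bears on this change is the earlier exchange on the same amide-type nitrogen, a number 1.5 percentage points lower from compound 1 to compound 2 (within the scatter), which moved nothing beyond the scatter; moreover the group entering compound 3 resembles the benzyl group of compound 1 more closely than the 2-methylphenyl group of compound 2. Compound 3 is therefore expected to show a number 1.2 percentage points higher from compound 2 to compound 3 (within the scatter), no step beyond the scatter in either direction. The estimate for compound 3 in this assay is 11%, with a range from 2% to 22%.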

Compound 3, a percentage reported as inhibition, in the whole organism at one dose (the size of the read-out at that dose, not a potency): 14.7%
Compound 3: middle estimate off by 3.7 percentage points, on the low side; the measured number falls inside the stated range.
By their numbers in this assay, from the lowest: compounds 2, 1 and 3 (each within the scatter of the next).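

In this assay, the amide-type nitrogen has now carried three different groups without any step beyond the scatter: (pyridin-3-yl)methyl, with 1 hydrogen-bond acceptor where 2-methylphenyl has 0, gives a number 4.9 percentage points higher from compound 2 to compound 3 (within the scatter) on this exchange. Among these compounds, the result also tests a change further out than the earlier compounds did, since pyridin-3-yl in place of phenyl on a saturated chain carbon bound to an amide-type nitrogen gives a number 3.4 percentage points higher from compound 1 to compound 3 (within the scatter) and so leaves compound 3 and compound 1 indistinguishable on this read-out. Nothing measured here explains these numbers.

As far as these compounds go, it remains open whether any group on this nitrogen can move the number beyond the scatter, for instance an aliphatic amine or a carboxylic acid at the end of the chain, or a longer chain between the nitrogen and the ring. Since the read-out gives only the size of the inhibition at one dose, the three compounds also leave open how the numbers would behave at other doses, and whether changes elsewhere on the shared core would matter more than changes at this position.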